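The source may hold more compounds than are shown below. What is called first, only, known or untested is meant among the compounds shown, and "the series" means these compounds.

Measured so far:
Compound 1, `O=S(=O)(c1cccc(F)c1)c1n[nH]c2cccc(N3CCNCC3)c12`, an assay on HeLa cells for displacement of a labelled ligand from 5-hydroxytryptamine receptor 6 (Homo sapiens); a higher number here means a weaker inhibitor, a lower number a stronger inhibitor: 134 nM
Compound 2, `CN1CCN(c2cccc3c(S(=O)(=O)c4cccc5ccccc45)n[nH]c23)CC1`, this assay: 4.6 nM

Among the measured compounds shown here, compound 1 has the higher of the two numbers; compound 2 sits well below it, beyond the scatter, but the two structures differ in more than one place, so their values show only that the pair differs, not what any single change does. Compound 3, `O=S(=O)(c1ccc(Cl)cc1)c1n[nH]c2cccc(N3CCNCC3)c12`, has not yet been measured in this assay. It differs from compound 1 in one place: 4-chlorophenyl in place of 3-fluorophenyl on a sulfonyl sulfur. For the measured compounds named here, no measured pair shows this change on the shared core, so the direction rests on expectation alone. The step from compound 1 to compound 3 is expected to be small, toward a lower number, and close to the edge of the scatter, a 1.9-fold lower number from compound 1 to compound 3 (0.28 log units; within the scatter). Compound 3 is accordingly expected to give about 70 nM in this assay, within a range from 25 nM to 250 nM.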

Compound 3, inhibition constant: 125 nM
Beside the measured number, compound 3's estimate is 1.8-fold (0.25 log units) below it; low and high end bracket the measured number.
By their numbers in this assay, from the lowest: compound 2; then compounds 3 and 1 (each within the scatter of the next).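

In this assay, among the compounds shown here, putting 4-chlorophenyl in place of 3-fluorophenyl on a sulfonyl sulfur gives a 1.1-fold lower number from compound 1 to compound 3 (0.03 log units; within the scatter) and so provides the first reading of a single change on the shared core. At this place, the two substituted phenyl groups cannot be told apart, as their values lie within the scatter of each other. No measured evidence bears on this result.

Since this change swaps the halogen and its place on the ring together, it does not separate the two, and a 3-chlorophenyl or 4-fluorophenyl group would be needed to do so. Also open, on these data alone, is whether a phenyl group carrying an amine or a carboxylic acid would give a similar value, and compound 2, at 4.6 nM, differs from compound 3 in more than one place, so no single change accounts for that gap.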